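The source may hold more compounds than are shown below. What is called first, only, known or untested is meant among the compounds shown, and "the series" means these compounds.

Compound 3, `CCN(CC)c1ccc2cc(C(=O)c3ccc(N4CCN(C(=O)CN5CCN(S(=O)(=O)c6ccc(C#N)cc6)CC5)CC4)cc3)oc2c1`, is one of three measured members of a series that share a core and differ only in the group on the amine nitrogen of the outer six-membered ring with two nitrogens. In a functional assay on MCF7 cells (Homo sapiens) for cytotoxicity, read by MTT assay, with a stated time of 48 h (on this read-out lower numbers stand for stronger inhibition and higher numbers for weaker inhibition), compound 3 reaches only a limit of the assay, > 40000 nM. Compound 1, `CCN(CC)c1ccc2cc(C(=O)c3ccc(N4CCN(C(=O)CN5CCN(C(=O)CCl)CC5)CC4)cc3)oc2c1`, likewise reaches only a limit, > 40000 nM. Compound 2, `CCN(CC)c1ccc2cc(C(=O)c3ccc(N4CCN(C(=O)CN5CCN(S(=O)(=O)c6ccc(OC(F)(F)F)cc6)CC5)CC4)cc3)oc2c1`, gives a number in this assay, 20100 nM. The step from compound 1 to compound 3 is a step that the two limits leave unreadable from compound 1 to compound 3, and the step from compound 2 to compound 3 is an at least 1.9-fold higher number from compound 2 to compound 3 (0.29 log units; that floor lies within the scatter), a floor that the scatter covers. Two of the three values stand at the same cap, (the limit of > 40000 nM in this assay, at which 2 of the 3 values shown sit), so compound 3 is placed only as weak, not as ranked among its neighbours.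

Compound 4, `CCN(CC)c1ccc2cc(C(=O)c3ccc(N4CCN(C(=O)CN5CCN(Cc6ccc(F)c(F)c6)CC5)CC4)cc3)oc2c1`, differs from compound 3 in one place: 3,4-difluorobenzyl in place of (4-cyanophenyl)sulfonyl on an amine nitrogen in a ring. Within the data shown here, no measured step exchanges a sulfonyl for a benzyl on that nitrogen, so the expectation for compound 4 in this assay rests on the weak range the three compounds span. Compound 4 is therefore expected near the cap, with the step from compound 3 to compound 4 estimated as an at least 1.2-fold lower number from compound 3 to compound 4 (0.09 log units; that floor lies within the scatter). The estimate for compound 4 in this assay is 32000 nM, within 10000 nM to 40000 nM.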

Compound 4, half-maximal inhibitory concentration: 9220 nM
Estimate against measurement, compound 4: 3.5-fold (0.54 log units) above; the measured number lies below the stated range.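

In this assay, this nitrogen of the outer ring is shown for the first time to move the number beyond the scatter: the change to 3,4-difluorobenzyl gives an at least 4.3-fold lower number from compound 3 to compound 4 (0.63 log units; beyond the scatter) and, from the chloromethyl carbonyl, an at least 4.3-fold lower number from compound 1 to compound 4 (0.63 log units; beyond the scatter). Among these compounds, until now, the only readable step at this position had a floor within the scatter, and it exchanged one substituent on the sulfonyl aryl ring rather than the group joined directly to the nitrogen. Both new steps are floors and not full sizes, as each starts from a compound held at a limit of the assay: the limit of > 40000 nM in this assay, at which 2 of the 4 values shown sit.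

The compounds shown do not separate the contribution of the benzyl link from that of the two fluorines, which an unsubstituted benzyl on the same nitrogen would address. They also leave open how a smaller group such as methyl, or the free secondary amine with only a hydrogen on that nitrogen, would read in this assay.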